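The source may report more compounds than this note shows. Statements on the series, on what has been measured and on what is new or still open speak of the compounds shown alone.

Measured compounds:
compound 1 `O=C(/C=C/c1ccc2c(c1)B(O)OC2)c1ccccc1O`: 48800 nM
compound 2 `COc1ccccc1C(=O)/C=C/c1ccc2c(c1)B(O)OC2`: 2600 nM

Both were tested in a functional assay on SK-OV-3 cells (Homo sapiens) for cytotoxicity, read by MTT assay, with a stated time of 48 h; on this read-out higher numbers stand for weaker inhibition and lower numbers for stronger inhibition. Compound 1 gives 48800 nM and compound 2 gives 2600 nM. For the measured compounds named here, the one measured step is a 19-fold lower number from compound 1 to compound 2 (1.27 log units; beyond the scatter), which leaves compound 2 as the lower of the two numbers; its nearest neighbour is compound 1.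

Compound 3 `COCOc1ccccc1C(=O)/C=C/c1ccc2c(c1)B(O)OC2` has not yet been measured. It differs from compound 2 by methoxy in place of hydrogen on a saturated chain carbon bound to an oxygen on an aromatic ring; seen one bond further out, the methyl becomes methoxymethyl and the methoxy becomes methoxymethoxy. Going by the values given here, the only step that bears on this change is a 19-fold lower number from compound 1 to compound 2 (1.27 log units; beyond the scatter), in which a methyl capped the same oxygen and the number fell sharply in this assay. Compound 3 keeps that cap and only lengthens it, so no large movement is expected. Compound 3 is therefore expected to show a 1.2-fold higher number from compound 2 to compound 3 (0.06 log units; within the scatter), with an estimate of 3000 nM and a likely range from 1000 nM to 9000 nM.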

Compound 3, half-maximal inhibitory concentration: 6500 nM
Estimate against measurement, compound 3: 2.2-fold (0.34 log units) below; the range from low to high includes it.
By their numbers in this assay, from the lowest: compound 2; then compound 3; then compound 1.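

In this assay, the cap on the oxygen on the aromatic ring is not a free choice: going from methyl to methoxymethyl costs some activity, with a 2.5-fold higher number from compound 2 to compound 3 (0.40 log units; beyond the scatter). Even so, the longer cap keeps much of the gain over plain hydrogen, with a 7.5-fold lower number from compound 1 to compound 3 (0.88 log units; beyond the scatter), so in these three compounds, having a cap on this oxygen matters more than which of the two caps it is. Nothing available explains why the longer cap does worse.

The compounds shown leave open whether the loss follows the greater length of the cap or the extra oxygen within it, a question that a propyl group on the same oxygen could help to settle. They also leave open how a cap ending in an amine or a carboxylic acid would behave.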